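This account rests on a few compounds, and the source may have more. Where it says the series, first, only, none or still open, it means among the compounds named here.

Compound 1 (`COc1ccc(-c2c[nH]c(=O)n2-c2cc(OC)c(OC)c(OC)c2)cc1N`) in a functional assay on K-562R cells (Homo sapiens) for cytotoxicity, read by MTT assay, with a stated time of 48 h (on this read-out lower numbers stand for stronger inhibition and higher numbers for weaker inhibition), gives > 50000 nM (a limit of the assay).
Compound 2 (`COc1ccc(-c2cn(C(C)=O)c(=O)n2-c2cc(OC)c(OC)c(OC)c2)cc1[N+](=O)[O-]`) in this assay gives > 50000 nM (a limit of the assay).

Within the data shown here, compound 2 therefore has no number, only a limit, and the same holds for the whole series so far (the limit of > 50000 nM in this assay, at which 2 of the 2 values shown sit). Compound 3 (`COc1ccc(-c2cn(C(C)=O)c(=O)n2-c2cc(OC)c(OC)c(OC)c2)cc1N`) differs from compound 2 by amino in place of nitro on an aromatic carbon, ortho to a methoxy group (amino in place of nitro on an aromatic carbon). Among the measured compounds shown here, no measured pair shows what such a change does in this assay. Compound 1 also carries an amino group, and its value (> 50000 nM) is likewise a limit. Any gain is thus expected to be modest. The expected step (an at least 2.5-fold lower number from compound 2 to compound 3 (0.39 log units; beyond the scatter)) points toward stronger inhibition, and compound 3 may well remain at the limit. Compound 3 is estimated at 20000 nM (expected range from 800 nM to 50000 nM).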

Compound 3, half-maximal inhibitory concentration: 49300 nM
The estimate for compound 3 lay 2.5-fold (0.39 log units) below the measured number; the range from low to high includes it.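

In this assay, among these compounds, compound 3 gives 49300 nM, the first actual number rather than a limit. Even so, the exchange of nitro for amino on the aromatic carbon, ortho to a methoxy group, reads an at least 1.0-fold lower number from compound 2 to compound 3 (0.00 log units; that floor lies within the scatter), so it is not shown to have any effect. The exchange of hydrogen for acetyl on the aromatic nitrogen reads an at least 1.0-fold lower number from compound 1 to compound 3 (0.00 log units; that floor lies within the scatter), so neither step shows a gain beyond the scatter.

Most of the series still rests at the ceiling of the measurement: the limit of > 50000 nM in this assay, at which 2 of the 3 values shown sit. It remains open whether a hydroxyl or dimethylamino group in place of the amino group, or a longer acyl chain such as butyryl in place of the acetyl, would give a number clearly lower than that of compound 3.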